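A Methyl Removed from Compound 2: Expecting Compound 4

The source may hold more compounds than are shown below. What is called first, only, known or untested is meant among the compounds shown, and "the series" means these compounds.

Three compounds of a shared core were measured in an assay on CHO cells for displacement of a labelled ligand from adenosine receptor A1 (Homo sapiens), read by scintillation counting, with a stated time of 90 min, in the presence of a further agent that is not named here; on this read-out higher numbers stand for weaker inhibition and lower numbers for stronger inhibition. Compound 2 `CCCn1c(=O)[nH]c2nc(-c3ccc(S(=O)(=O)N4CCN(c5ccccc5C)CC4)cc3)[nH]c2c1=O` gives 419 nM and is the only one of the three with a number rather than a limit. Compound 1 `CCCn1c(=O)[nH]c2nc(-c3ccc(S(=O)(=O)N4CCN(c5ccc(F)cc5)CC4)cc3)[nH]c2c1=O` gives only a limit of the assay, > 1000 nM. Compound 3 `CCCn1c(=O)[nH]c2nc(-c3ccc(S(=O)(=O)N4CCN(c5ccc(C)cc5)CC4)cc3)[nH]c2c1=O` likewise gives only a limit, > 1000 nM. The step from compound 1 to compound 2, 2-methylphenyl in place of 4-fluorophenyl on an amine nitrogen in a ring, is an at least 2.3-fold lower number from compound 1 to compound 2 (0.37 log units; beyond the scatter), and the step from compound 2 to compound 3, 4-methylphenyl in place of 2-methylphenyl, is an at least 2.3-fold higher number from compound 2 to compound 3 (0.37 log units; beyond the scatter). The step from compound 1 to compound 3 cannot be read because of the limit of > 1000 nM in this assay, at which 2 of the 3 values shown sit.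

Compound 4 `CCCn1c(=O)[nH]c2nc(-c3ccc(S(=O)(=O)N4CCN(c5ccccc5)CC4)cc3)[nH]c2c1=O` differs from compound 2 by hydrogen in place of methyl on an aromatic carbon. Within the data shown here, no measured pair removes this methyl outright, but both measured steps show that compound 2, with the methyl ortho to a large group, stands apart from the two compounds that lack it there. Compound 4 is therefore expected to lose some of that advantage: the step from compound 2 to compound 4 in this assay is estimated as a 2.1-fold higher number from compound 2 to compound 4 (0.33 log units; beyond the scatter). Compound 4 is estimated at 900 nM, within 350 nM to 2500 nM, with a fair chance that only a limit is reported.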

Compound 4, inhibition constant: 364 nM
For compound 4 the middle estimate is 2.5-fold (0.39 log units) above the measured one; measured number inside the range.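

In this assay, the change from 2-methylphenyl to phenyl gives a 1.2-fold lower number from compound 2 to compound 4 (0.06 log units; within the scatter) and so shows that the methyl on this aromatic carbon, ortho to a large group, is not what sets compound 2 apart from compound 1 and compound 3. Compound 4 shares that separation, since hydrogen in place of the methyl of compound 3 gives an at least 2.7-fold lower number from compound 3 to compound 4 (0.43 log units; beyond the scatter) and hydrogen in place of the fluoro of compound 1 gives an at least 2.7-fold lower number from compound 1 to compound 4 (0.43 log units; beyond the scatter) as well. Among these compounds, the gap that the earlier compounds tied to the methyl of compound 2 therefore goes instead with the methyl of compound 3 and the fluoro of compound 1, and these two steps have a bound on one side only because each starts from a limit of the assay: the limit of > 1000 nM in this assay, at which 2 of the 4 values shown sit.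

As far as these compounds go, how far compound 1 and compound 3 truly lie from compound 4 remains open. The compounds shown also leave open whether a larger group ortho to the same large group, such as ethyl or methoxy, would be tolerated as the methyl is, or whether chloro would behave like either.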